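The source may hold more compounds than are shown below. What is called first, only, known or untested is meant among the compounds shown, and "the series" means these compounds.

Working notes on the series. The shared core carries a chain on the aromatic nitrogen: methyl in compound 1 (`Cc1ccc(-c2cs/c(=N\C(=O)c3ccccc3)n2C)c(C)c1`), ethyl in compound 2 (`CCn1c(-c2ccc(C)cc2C)cs/c1=N\C(=O)c1ccccc1`) and propyl in compound 3 (`CCCn1c(-c2ccc(C)cc2C)cs/c1=N\C(=O)c1ccccc1`). In a functional assay on MDA-MB-231 cells (Homo sapiens), read by microscopy and transwell migration, with a stated time of 24 h (a lower number here means a stronger inhibitor, a higher number a weaker inhibitor), compound 1 gives 218 nM, compound 2 gives 1950 nM and compound 3 gives 292 nM. Going by the values given here, compound 3 therefore stands within the scatter of compound 1 and well under compound 2, which has the highest number so far.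

The next member is compound 4 (`CCCCn1c(-c2ccc(C)cc2C)cs/c1=N\C(=O)c1ccccc1`), the butyl analogue of compound 3: methyl in place of hydrogen on a saturated chain carbon, three bonds along the chain from an aromatic nitrogen. This places methyl in place of hydrogen on a saturated chain carbon, three bonds along the chain from an aromatic nitrogen, taking propyl to butyl.

Among the compounds with values here, three measured steps bear on this change. The first extension gave an 8.9-fold higher number from compound 1 to compound 2 (0.95 log units; beyond the scatter), and the next reversed it with a 6.7-fold lower number from compound 2 to compound 3 (0.82 log units; beyond the scatter). Across both, the result is a 1.3-fold higher number from compound 1 to compound 3 (0.13 log units; within the scatter). Chain growth thus shows no single direction in these three compounds, and compound 2 goes against any steady trend.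

The expectation therefore stays close to compound 3 at 292 nM, with no step beyond the scatter foreseen in this assay and only a slight lean upward. The expected step is a 1.4-fold higher number from compound 3 to compound 4 (0.14 log units; within the scatter). The estimate for compound 4 is 400 nM, with an expected range of 130 nM to 1700 nM.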

Compound 4, half-maximal inhibitory concentration: 196 nM
Estimate against measurement, compound 4: 2.0-fold (0.31 log units) above, and the stated range covers the measured number.
By their numbers in this assay, from the lowest: compounds 4, 1 and 3 (each within the scatter of the next); then compound 2.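

Taking propyl to butyl, with methyl in place of hydrogen on a saturated chain carbon, three bonds along the chain from an aromatic nitrogen, gives in this assay a 1.5-fold lower number from compound 3 to compound 4 (0.17 log units; within the scatter), and a 1.1-fold lower number from compound 1 to compound 4 (0.05 log units; within the scatter) shows that butyl also remains within the scatter of the methyl chain. Compound 2 now stands apart as the one chain that goes against this flat pattern, with a 9.9-fold lower number from compound 2 to compound 4 (1.00 log units; beyond the scatter), and adding ethyl does not carry a fixed result from one core to the next: the same change on two cores in this assay, a 1.3-fold higher number (0.13 log units; within the scatter) from compound 1 to compound 3 and a 9.9-fold lower number (1.00 log units; beyond the scatter) from compound 2 to compound 4, 13-fold (1.12 log units) apart, beyond the scatter of two such steps. Adding methyl likewise depends on the chain that receives it, so chain length alone gives no steady trend across the four compounds: the same change on two cores in this assay, an 8.9-fold higher number (0.95 log units; beyond the scatter) from compound 1 to compound 2 and a 1.5-fold lower number (0.17 log units; within the scatter) from compound 3 to compound 4, 13-fold (1.12 log units) apart, beyond the scatter of two such steps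

The compounds shown leave open whether the flat pattern from propyl to butyl continues to a pentyl or hexyl chain, or holds for a branched isopropyl chain. They also leave open whether a chain ending in a hydroxyl group or an amine would stay with compounds 1, 3 and 4 or move toward compound 2.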